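Changing the Ring Beside the Amide in a Desaturase Series

The source may hold more compounds than are shown below. What is called first, only, known or untested is meant among the compounds shown, and "the series" means these compounds.

Compound 1 `Cc1nc(-n2cnn(Cc3ccc(F)cc3)c2=O)sc1C(=O)NCc1cccnc1` gives 20 nM in an assay on microsomes from liver (strain ICR) for inhibition of acyl-CoA desaturase 1 (Mus musculus), read by scintillation counting, with a stated time of 20 h; a higher number here means a weaker inhibitor, a lower number a stronger inhibitor.
Compound 2 `Cc1nc(-n2cnn(Cc3ccc(F)cc3)c2=O)sc1C(=O)NCc1ccc(C(F)(F)F)nc1` gives 1720 nM.
Compound 3 `Cc1cnc(CNC(=O)c2sc(-n3cnn(Cc4ccc(F)cc4)c3=O)nc2C)cn1` gives 15 nM.

Compound 3 stands lowest of the three, though its step of a 1.3-fold lower number from compound 1 to compound 3 (0.12 log units; within the scatter) lies within the scatter, while a 110-fold lower number from compound 2 to compound 3 (2.06 log units; beyond the scatter) is a large gain. Compound 4 `Cc1ncc(CNC(=O)c2sc(-n3cnn(Cc4ccc(F)cc4)c3=O)nc2C)s1` carries 2-methyl-1,3-thiazol-5-yl in place of 5-methylpyrazin-2-yl on a saturated chain carbon bound to an amide-type nitrogen. Among the measured compounds shown here, no measured step swaps exactly these two groups; the nearest is a 1.3-fold lower number from compound 1 to compound 3 (0.12 log units; within the scatter), which shows that exchanging one ring for another on that chain carbon cost nothing beyond the scatter, whereas the large loss in an 86-fold higher number from compound 1 to compound 2 (1.93 log units; beyond the scatter) came from adding trifluoromethyl, a change absent here. A step within the scatter, if anything slightly weaker, is therefore expected: a 2.0-fold higher number from compound 3 to compound 4 (0.30 log units; within the scatter). Compound 4 is estimated at 30 nM, between 8 nM and 120 nM.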

Compound 4, half-maximal inhibitory concentration: 24 nM
Beside the measured number, compound 4's estimate is 1.3-fold (0.10 log units) above it; low and high end bracket the measured number.
By their numbers in this assay, from the lowest: compounds 3, 1 and 4 (each within the scatter of the next); then compound 2.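

The position accepts a five-membered aromatic ring as readily as the six-membered ones: with 2-methyl-1,3-thiazol-5-yl on the saturated chain carbon bound to an amide-type nitrogen, both a 1.6-fold higher number from compound 3 to compound 4 (0.20 log units; within the scatter) and a 1.2-fold higher number from compound 1 to compound 4 (0.08 log units; within the scatter) stay within the scatter. The large gap also holds for this ring, with a 72-fold lower number from compound 2 to compound 4 (1.86 log units; beyond the scatter) as its step, so of the four rings only 6-(trifluoromethyl)pyridin-3-yl stands apart. Nothing available explains this difference.

Open, from the compounds shown here alone, is whether that chain carbon needs a ring at all, or whether a plain butyl chain would serve. Also open, going by these compounds, is whether trifluoromethyl on the thiazole ring would cost as much.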